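The source may hold more compounds than are shown below. What is called first, only, known or untested is meant among the compounds shown, and "the series" means these compounds.

Compound 1 `COc1ccc(Nc2nnc(-c3ccccc3Cl)s2)cc1` gives 22600 nM in an assay on isolated protein for inhibition of beta-glucuronidase (Bos taurus), read by spectrophotometry, with a stated time of 30 min; on this read-out higher numbers stand for weaker inhibition and lower numbers for stronger inhibition.
Compound 2 `Clc1ccc(Nc2nnc(-c3ccccc3Cl)s2)cc1Cl` gives 2160 nM in this assay.
Compound 3 `CC(C)(C)c1ccc(-c2nnc(Nc3ccc(Br)cc3)s2)cc1` gives 32200 nM in this assay.

Compound 2 stands lowest of the three numbers in this assay. Its nearest neighbour is compound 1, whose number is higher by a gap beyond the scatter; compound 3 lies furthest, also beyond the scatter. Among the compounds with values here, compounds 1 and 3 differ from compound 2 in more than one place, so no single step between measured compounds can be read off.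

Compound 4 `Clc1ccc(Nc2nnc(-c3ccccc3)s2)cc1Cl` has not yet been measured in this assay. It differs from compound 2 in this way: hydrogen in place of chloro on an aromatic carbon

Within the data shown here, no measured pair shows what this particular change does here. The surrounding numbers come from compounds that change several things at once, so the step from compound 2 to compound 4 is expected to be a modest weakening, written as a 2.3-fold higher number from compound 2 to compound 4 (0.36 log units; beyond the scatter). For compound 4 the estimate in this assay is 5000 nM, with a range from 1500 nM to 16000 nM.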

Compound 4, half-maximal inhibitory concentration: 6280 nM
For compound 4 the middle estimate is 1.3-fold (0.10 log units) below the measured one; the measured number falls inside the stated range.
By their numbers in this assay, from the lowest: compound 2; then compound 4; then compounds 1 and 3 (each within the scatter of the next).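

Within the data shown here, replacing the chloro group with hydrogen, the change from 2-chlorophenyl to phenyl, gives a 2.9-fold higher number from compound 2 to compound 4 (0.46 log units; beyond the scatter) in this assay and provides the first single-place step in this set. At this carbon, ortho to a large group, the chloro group is therefore linked to stronger inhibition, but it is not required: compound 4 still gives a measurable value of 6280 nM without it. No evidence at hand accounts for the size of this step.

With only chloro and hydrogen seen at this carbon, the compounds shown leave open how a fluoro, methoxy, hydroxyl or amine group there would compare. From the compounds shown here alone, it also remains open whether the same 2-chlorophenyl to phenyl change would give a similar step on the methoxy-bearing compound 1.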